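Longer unsaturated acyl group on the shared amide core

The source may hold more compounds than are shown below. What is called first, only, known or untested is meant among the compounds shown, and "the series" means these compounds.

Compound 1, `COc1ccc(CN(C(C)=O)c2cc(OC)c(OC)c(OC)c2)cc1O`, gives 270 nM in a functional assay on HCT-116 cells (Homo sapiens) for inhibition, read by MTT assay, with a stated time of 48 h; on this read-out higher numbers stand for weaker inhibition and lower numbers for stronger inhibition.
Compound 2, `COc1ccc(CN(C(=O)C(C)Br)c2cc(OC)c(OC)c(OC)c2)cc1O`, gives 140 nM in this assay.
Compound 3, `C=C(C)C(=O)N(Cc1ccc(OC)c(O)c1)c1cc(OC)c(OC)c(OC)c1`, gives 200 nM in this assay.

Compound 3 holds the second highest of these three numbers. Its nearest neighbour is compound 1, as the step of a 1.4-fold lower number from compound 1 to compound 3 (0.13 log units; within the scatter) shows, and the step of a 1.4-fold higher number from compound 2 to compound 3 (0.15 log units; within the scatter) places compound 2 a little further away; neither separation is beyond the scatter. Compound 4, `CCC/C=C/C(=O)N(Cc1ccc(OC)c(O)c1)c1cc(OC)c(OC)c(OC)c1`, differs from compound 3 by pent-1-en-1-yl in place of 1-methylethenyl on a carbonyl carbon. Going by the values given here, every measured step so far alters the group on this same carbonyl carbon: a 1.9-fold lower number from compound 1 to compound 2 (0.29 log units; within the scatter), a 1.4-fold lower number from compound 1 to compound 3 (0.13 log units; within the scatter) and a 1.4-fold higher number from compound 2 to compound 3 (0.15 log units; within the scatter), all within the scatter. As far as these compounds go, none of them introduces a group as long as pent-1-en-1-yl, so its effect is untested, but the three earlier exchanges at this place moved the number very little. The step of a 1.5-fold higher number from compound 3 to compound 4 (0.18 log units; within the scatter) is therefore expected to stay within the scatter. Compound 4 is estimated to give 300 nM in this assay, with a range from 120 nM to 800 nM.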

Compound 4, half-maximal inhibitory concentration: 95 nM
Beside the measured number, compound 4's estimate is 3.2-fold (0.50 log units) above it; the whole stated range lies above it.
By their numbers in this assay, from the lowest: compounds 4, 2, 3 and 1 (each within the scatter of the next, the first and the last beyond it).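

In this assay, going by these compounds alone, the group pent-1-en-1-yl gives the first steps at this carbonyl carbon that lie beyond the scatter, with a 2.1-fold lower number from compound 3 to compound 4 (0.32 log units; beyond the scatter) and a 2.8-fold lower number from compound 1 to compound 4 (0.45 log units; beyond the scatter) both modest in size. The position therefore responds to a change of acyl group, which the three earlier exchanges among methyl, 1-bromoethyl and 1-methylethenyl did not show. The response does not set compound 4 apart from every earlier compound, since 1-bromoethyl remains close with a 1.5-fold lower number from compound 2 to compound 4 (0.17 log units; within the scatter) and no order can be drawn between that pair. Nothing available here accounts for the change in the number.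

The compounds shown do not separate the length of the pent-1-en-1-yl chain from its double bond, which a saturated pentyl group could test. They also leave open whether a longer chain, such as hept-1-en-1-yl, would carry the trend further or reverse it.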